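The source may hold more compounds than are shown below. What is called first, only, known or untested is meant among the compounds shown, and "the series" means these compounds.

In a functional assay for antagonist activity at transient receptor potential cation channel subfamily V member 1 (Homo sapiens) (on this read-out lower numbers stand for stronger inhibition and higher numbers for weaker inhibition), compound 3 `O=C(O)CCc1nc(Nc2ccc(C(F)(F)F)cc2)c2ccc(-c3ncccc3C(F)(F)F)cc2n1` gives 1630 nM, the highest number of the three measured. Compound 1 `CCOCc1nc(Nc2ccc(C(F)(F)F)cc2)c2ccc(-c3ncccc3C(F)(F)F)cc2n1` gives 0.9 nM and compound 2 `CC(C)OCc1nc(Nc2ccc(C(F)(F)F)cc2)c2ccc(-c3ncccc3C(F)(F)F)cc2n1` gives 0.3 nM. The two steps that lead to compound 3 are both large: a 1800-fold higher number from compound 1 to compound 3 (3.26 log units; beyond the scatter) and a 5400-fold higher number from compound 2 to compound 3 (3.74 log units; beyond the scatter), each putting a carboxymethyl where an ethoxy or isopropoxy stood on the saturated chain carbon bound to an aromatic carbon. Compound 4 `FC(F)(F)c1ccc(Nc2nc(CN3CCCC3)nc3cc(-c4ncccc4C(F)(F)F)ccc23)cc1` removes that carboxymethyl: pyrrolidin-1-yl in place of carboxymethyl on a saturated chain carbon bound to an aromatic carbon. Because a 1800-fold higher number from compound 1 to compound 3 (3.26 log units; beyond the scatter) and a 5400-fold higher number from compound 2 to compound 3 (3.74 log units; beyond the scatter) were both sharp rises, taking the carboxymethyl away is expected to lower the number by a large amount, though whether pyrrolidin-1-yl reaches the level of compound 1 is not known. Compound 4 is therefore estimated at 3 nM, within 0.5 nM to 30 nM, a step of a 540-fold lower number from compound 3 to compound 4 (2.74 log units; beyond the scatter).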

Compound 4, half-maximal inhibitory concentration: 25 nM
Compound 4: the middle estimate sits 8.3-fold (0.92 log units) below what was measured; the measured number falls inside the stated range.
By their numbers in this assay, from the lowest: compound 2; then compound 1; then compound 4; then compound 3.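

Putting pyrrolidin-1-yl in place of carboxymethyl on the saturated chain carbon bound to an aromatic carbon recovers much of the lost inhibition (a 65-fold lower number from compound 3 to compound 4 (1.81 log units; beyond the scatter)), so a low number at this position does not depend on an ether oxygen. Even so, pyrrolidin-1-yl does not match either ether group (a 28-fold higher number from compound 1 to compound 4 (1.44 log units; beyond the scatter); an 83-fold higher number from compound 2 to compound 4 (1.92 log units; beyond the scatter)), so the choice of group here still matters. Nothing measured here explains these differences.

On these data alone, it remains open whether another amine, such as piperidine, morpholine or dimethylamine, would come closer to compound 1 and compound 2.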